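Swapping Hydroxy for Methyl on the Shared Core

The source may report more compounds than this note shows. Statements on the series, on what has been measured and on what is new or still open speak of the compounds shown alone.

In a functional assay on HT-29 cells (Homo sapiens) for inhibition, read by MTT assay (a lower number here means a stronger inhibitor, a higher number a weaker inhibitor), two compounds with the same core have been measured. Compound 1 `COc1ccc(/C=C2\c3cc(OC)c(OC)c(OC)c3CC[C@H]2O)cc1C#N`, which carries a cyano group, gives 200 nM. Compound 2 `COc1ccc(/C=C2\c3cc(OC)c(OC)c(OC)c3CC[C@H]2O)cc1O`, with hydroxy on that aromatic carbon instead, gives 790 nM, the higher of the two numbers and so the weaker inhibitor of the pair. Going by the values given here, the only measured step is a 4.0-fold higher number from compound 1 to compound 2 (0.60 log units; beyond the scatter), a modest change at the same carbon now under consideration.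

Compound 3 `COc1ccc(/C=C2\c3cc(OC)c(OC)c(OC)c3CC[C@H]2O)cc1C` has not been measured. It differs from compound 2 by methyl in place of hydroxy on an aromatic carbon, ortho to a methoxy group, turning 3-hydroxy-4-methoxyphenyl to 4-methoxy-3-methylphenyl. Among the compounds with values here, no measured compound carries methyl here, so the one available step, a 4.0-fold higher number from compound 1 to compound 2 (0.60 log units; beyond the scatter), offers only a rough guide to size and direction. It does show that hydroxy gave the higher number of the two groups tested. A small move towards a lower number is therefore expected, with the estimated step being a 1.6-fold lower number from compound 2 to compound 3 (0.20 log units; within the scatter). For compound 3 the estimated value is 500 nM, within an expected range of 150 nM to 1700 nM.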

Compound 3, half-maximal inhibitory concentration: 3970 nM
Compound 3: the middle estimate sits 7.9-fold (0.90 log units) below what was measured; the whole stated range lies below it.
By their numbers in this assay, from the lowest: compound 1; then compound 2; then compound 3.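

In this assay, going by these compounds alone, this carbon, ortho to a methoxy group, proves more sensitive to its substituent than the one earlier step could show: methyl in place of hydroxy gives a 5.0-fold higher number from compound 2 to compound 3 (0.70 log units; beyond the scatter) and hydroxy is therefore not the least favourable of the groups seen here, but sits between the other two. Methyl in place of cyano gives a 20-fold higher number from compound 1 to compound 3 (1.30 log units; beyond the scatter) and this large step sets the span of the series, with the order cyano, hydroxy, methyl running from the lowest number to the highest and each step lying beyond the scatter. Hydroxy brings a hydrogen-bond donor and a hydrogen-bond acceptor while methyl brings neither, yet no measurement available here explains why the number rises with this change. From the compounds shown here alone, what remains open is where an amine, a chlorine atom or a carboxylic acid on this same carbon would fall relative to cyano, hydroxy and methyl. A longer chain such as ethyl is equally untested among the compounds shown, so it is unknown whether the rise seen with methyl would continue, level off or reverse.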